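Carbonyl-side exchange in the shared core series

The compounds below may be only part of what the source reports. "The series", "measured", "known", "first", "only" and "open" are said of these compounds alone.

In a functional assay on cells (Lymphocyte) (on this read-out lower numbers stand for stronger inhibition and higher numbers for weaker inhibition), compound 3 `Nc1nc(N2CCN(C(=O)COc3ccc(Br)cc3)CC2)c2ccsc2n1` gives 320 nM, the second highest of the three numbers. Compound 1 `Nc1nc(N2CCN(C(=O)COc3ccc(Cl)cc3)CC2)c2ccsc2n1` gives 330 nM in this assay, and compound 2 `COc1ccc(OCC(=O)N2CCN(c3nc(N)nc4sccc34)CC2)cc1` gives 72 nM. The step of a 1.0-fold lower number from compound 1 to compound 3 (0.01 log units; within the scatter) lies within the scatter, while a 4.6-fold lower number from compound 1 to compound 2 (0.66 log units; beyond the scatter) and a 4.4-fold higher number from compound 2 to compound 3 (0.65 log units; beyond the scatter) are modest. Compound 4 `Cc1cccc(NC(=O)N2CCN(c3nc(N)nc4sccc34)CC2)c1` is not yet measured; its difference from compound 3 is (3-methylphenyl)amino in place of (4-bromophenoxy)methyl on a carbonyl carbon. All three measured steps exchange a group on an aromatic carbon and leave the carbonyl carbon untouched, so none bears directly on this change. Going by the values given here, with no comparable step known, compound 4 is expected to show a 1.3-fold lower number from compound 3 to compound 4 (0.11 log units; within the scatter) in this assay, with wide uncertainty. Compound 4 is therefore estimated at 250 nM in this assay, in a range from 60 nM to 1000 nM.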

Compound 4, half-maximal inhibitory concentration: 930 nM
Compound 4: the middle estimate sits 3.7-fold (0.57 log units) below what was measured, within the range that was stated.
By their numbers in this assay, from the lowest: compound 2; then compounds 3 and 1 (each within the scatter of the next); then compound 4.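

In this assay, the whole group on the carbonyl carbon can be exchanged with a measurable effect: (3-methylphenyl)amino for (4-bromophenoxy)methyl gives a 2.9-fold higher number from compound 3 to compound 4 (0.46 log units; beyond the scatter) and, for (4-chlorophenoxy)methyl, a 2.8-fold higher number from compound 1 to compound 4 (0.45 log units; beyond the scatter) in the same direction. Both steps are modest and nearly equal, so here the halogen on the departing group makes no visible difference. Nothing measured here accounts for the shift.

The step alters the link to the ring and the ring substituent together, so their shares stay unresolved. Going by these compounds, whether (4-methoxyphenyl)amino or a plain phenylamino group would fare better on this carbonyl carbon remains open.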